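Swapping the basic amine tail: piperidine to methylpiperazine

The source may report more compounds than this note shows. Statements on the series, on what has been measured and on what is new or still open speak of the compounds shown alone.

Compound 1 `COc1cc2c(Oc3ccc(NC(=O)c4nn(-c5ccccc5OC(F)(F)F)c(=O)cc4C)cc3F)ccnc2cc1OCCCN1CCN(C)CC1`: 1440 nM
Compound 2 `COc1ccc(-n2nc(C(=O)Nc3ccc(Oc4ccnc5cc(OCCCN6CCN(C)CC6)c(OC)cc45)c(F)c3)c(C)cc2=O)cc1`: "not determined" (no result reported)
Compound 3 `COc1cc2c(Oc3ccc(NC(=O)c4nn(-c5ccc(Cl)cc5)c(=O)cc4C)cc3F)ccnc2cc1OCCCN1CCCCC1`: 1400 nM

In a functional assay on U-87MG ATCC cells (Homo sapiens) for inhibition, read by MTT assay, with a stated time of 72 h (on this read-out lower numbers stand for stronger inhibition and higher numbers for weaker inhibition), compound 3 gives 1400 nM, the lowest of the two numbers, and compound 1 sits with 1440 nM, within the scatter of it. For compound 2 no result was reported. Compound 4 `COc1cc2c(Oc3ccc(NC(=O)c4nn(-c5ccc(Cl)cc5)c(=O)cc4C)cc3F)ccnc2cc1OCCCN1CCN(C)CC1` differs from compound 3 in one place: 4-methylpiperazin-1-yl in place of piperidin-1-yl on a saturated chain carbon, three bonds along the chain from an oxygen on an aromatic ring. Going by the values given here, no measured pair shows this exact change, but compound 1, which already carries the 4-methylpiperazin-1-yl tail, gives 1440 nM, indistinguishable from compound 3. The step from compound 3 to compound 4 is therefore expected to be no change at the digits printed from compound 3 to compound 4 (within the scatter), none beyond the scatter. For compound 4 the estimate in this assay is 1400 nM, in the range 600 nM to 3500 nM.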

Compound 4, half-maximal inhibitory concentration: 1560 nM
Estimate against measurement, compound 4: 1.1-fold (0.05 log units) below, and the stated range covers the measured number.
By their numbers in this assay, from the lowest: compounds 3, 1 and 4 (each within the scatter of the next).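

In this assay the change from piperidin-1-yl to 4-methylpiperazin-1-yl on the chain now has a direct reading, with a 1.1-fold higher number from compound 3 to compound 4 (0.05 log units; within the scatter), so the two tails are not told apart at this place. The aryl group on the aromatic nitrogen also has its first direct reading, as 4-chlorophenyl in place of 2-(trifluoromethoxy)phenyl gives a 1.1-fold higher number from compound 1 to compound 4 (0.03 log units; within the scatter). No measurement shown offers a reason for either result. The compounds shown leave open whether a morpholin-4-yl tail or a 2-(piperidin-1-yl)ethyl chain would read differently in this assay.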